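The source may hold more compounds than are shown below. What is called first, only, known or untested is meant among the compounds shown, and "the series" means these compounds.

Measured so far:
- compound 1, `COc1ccc(-c2c(C#N)c(N)nc(SCc3csc(-c4ccccc4Cl)n3)c2C#N)cc1`: 11 nM in an assay on CHO cells for displacement of a labelled ligand from adenosine receptor A1 (Homo sapiens); on this read-out higher numbers stand for weaker inhibition and lower numbers for stronger inhibition
- compound 2, `COc1ccc(-c2c(C#N)c(N)nc(SCc3csc(-c4ccc(I)cc4)n3)c2C#N)cc1`: 3.9 nM in this assay

Among the measured compounds shown here, compound 2 holds the lowest of the two numbers in this assay; the only neighbour, compound 1, sits above it, and the gap between them, a 2.8-fold lower number from compound 1 to compound 2 (0.45 log units; beyond the scatter), is beyond the scatter.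

The next compound, compound 3, `COc1ccc(-c2c(C#N)c(N)nc(SCc3csc(-c4ccc(Cl)cc4)n3)c2C#N)cc1`, differs from compound 2 in one place: chloro in place of iodo on an aromatic carbon. The place is an aromatic carbon of a six-membered aromatic ring of carbon only, para to a large group.

For the measured compounds named here, only one measured step exists, the one from compound 1 to compound 2, and it changes both the halogen and its position on the ring at once. Going by the values given here, it therefore does not isolate the swap of iodo for chloro at the same position, and no step does. What it shows is that the para-halogen arrangement of compound 2 gives the lower number of the two. With chloro in place of iodo at that same position, a small drift toward a higher number is expected, within or just beyond the scatter, estimated as a 1.7-fold higher number from compound 2 to compound 3 (0.22 log units; within the scatter).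

For compound 3 in this assay the estimate is 6.5 nM, with a range from 2.5 nM to 16 nM.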

Compound 3, inhibition constant: 5 nM
For compound 3 the middle estimate is 1.3-fold (0.11 log units) above the measured one; the measured number falls inside the stated range.
By their numbers in this assay, from the lowest: compounds 2 and 3 (each within the scatter of the next); then compound 1.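

In this assay the exchange of iodo for chloro at this aromatic carbon, para to a large group, can now be read on its own: a 1.3-fold higher number from compound 2 to compound 3 (0.11 log units; within the scatter) stays within the scatter, so these two halogens are not told apart at this place. The second new step holds the halogen fixed and changes only its place on the ring, with 4-chlorophenyl in place of 2-chlorophenyl: a 2.2-fold lower number from compound 1 to compound 3 (0.34 log units; beyond the scatter) is modest but beyond the scatter, which shows that a change of place alone, with chloro on both sides, separates two compounds in this series. No data in hand bear on the reason for either step.

The compounds shown carry only chloro or iodo on this ring, so the outcome with an amine, a carboxylic acid or a longer chain on the same aromatic carbon stays open. Also open, as far as these compounds go, is whether the near-equality of 4-iodophenyl and 4-chlorophenyl holds on any read-out other than this assay and on any other receptor.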